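Stretching a Methyl into a Propyl on Compound 1

The source may hold more compounds than are shown below. What is called first, only, known or untested is meant among the compounds shown, and "the series" means these compounds.

In a functional assay on MCF7 cells (Homo sapiens) for antiproliferative activity, read by sulforhodamine B assay, with a stated time of 48 h (on this read-out lower numbers stand for stronger inhibition and higher numbers for weaker inhibition), compound 1 `CN1CCN(c2ccc(S(=O)(=O)Oc3c(Cl)cc(Cl)cc3Cl)cc2)C1=O` gives 2900 nM, the higher of the two numbers available. Compound 2 `COc1cc(OS(=O)(=O)c2ccc(N3CCN(C)C3=O)cc2)cc(OC)c1OC` gives 120 nM, and this gap lies beyond the usual scatter. Compound 3 `CCCN1CCN(c2ccc(S(=O)(=O)Oc3c(Cl)cc(Cl)cc3Cl)cc2)C1=O` keeps the core of compound 1 and changes it in one place: ethyl in place of hydrogen on a saturated chain carbon bound to an amide-type nitrogen in a ring. Put simply, ethyl takes the place of hydrogen on a saturated chain carbon bound to an amide-type nitrogen in a ring, so methyl becomes propyl. Among the compounds with values here, no pair of measured compounds shows this change on its own, so the data offer no direct guide to its size. No step beyond the scatter is therefore expected in this assay, and neither direction is favoured. The estimated step of a 1.2-fold lower number from compound 1 to compound 3 (0.06 log units; within the scatter) is correspondingly small. For compound 3 the estimated value is 2500 nM, with an expected range from 800 nM to 8000 nM.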

Compound 3, half-maximal inhibitory concentration: > 100000 nM
Compound 3: a limit, no number; the forecaster's own chance of this, stated with the estimate: 10%; middle value at least 40-fold (1.60 log units) from the limit.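

Compound 3 gives a limit of the assay and not a number: the limit of > 100000 nM in this assay, at which 1 of the 3 values shown sits.

Even so, the limit is enough to fix a minimum size for the change: stretching methyl into propyl gives an at least 34-fold higher number from compound 1 to compound 3 (1.53 log units; beyond the scatter). Within the data shown here, until now, no compound had varied this place, and this step shows that this assay is highly sensitive to what sits on the saturated chain carbon bound to the amide-type nitrogen in the ring, even when the group entering is only an ethyl.

The compounds shown do not say why the added ethyl has such a large effect, or whether the same change would have a similar effect on the core of compound 2. They also leave open where the loss begins, since an ethyl chain at this nitrogen, or a chain ending in a hydroxyl group, could fall on either side of it.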